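Halogenated anilide analogue of compound 1: expected inhibition

A few compounds are considered here, and "the series" means these few. Any claim that something is new, unique, unknown or untested is made for them only; others in the source may bear on it.

Measured compounds:
- compound 1, `CCOC(=O)C1=Cc2ccccc2OC1(OCc1cn(CC(=O)Nc2ccc(C)cc2)nn1)C(F)(F)F`: > 150000 nM
- compound 2, `Cc1ccc(-c2cc(COC3(C(F)(F)F)Oc4ccccc4C=C3C(=O)O)on2)cc1`: 41400 nM
- compound 3, `O=C(O)C1=Cc2ccccc2OC1(OCc1cc(-c2ccc3ccccc3c2)no1)C(F)(F)F`: 141000 nM

In a functional assay on DU-145 cells (Homo sapiens) for inhibition, read by MTT assay, with a stated time of 24 h (a lower number here means a stronger inhibitor, a higher number a weaker inhibitor), compound 1 returns only a limit, > 150000 nM, so its position is known solely as being at the ceiling of the measurement, (the limit of > 150000 nM in this assay, at which 1 of the 3 values shown sits). Compound 2 gives 41400 nM in this assay, and compound 3 gives 141000 nM. Among the measured compounds shown here, the single measured step, a 3.4-fold higher number from compound 2 to compound 3 (0.53 log units; beyond the scatter), concerns an aryl exchange on a ring carbon in the acid branch of the series and says nothing directly about the amide-type nitrogen.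

Compound 4, `CCOC(=O)C1=Cc2ccccc2OC1(OCc1cn(CC(=O)Nc2ccc(I)cc2Cl)nn1)C(F)(F)F`, differs from compound 1 by 2-chloro-4-iodophenyl in place of 4-methylphenyl on an amide-type nitrogen. For the measured compounds named here, no measured step touches this position, and compound 1 itself carries only a limit, so there is no quantitative anchor for the size of the change. Going by the values given here, the one comparable aryl swap was modest, which suggests that an aryl exchange here is unlikely to move the number far from where compound 1 sits.

Compound 4 is therefore expected to remain near the ceiling of this assay, estimated at 200000 nM with a range of 50000 nM to 800000 nM. The step from compound 1 to compound 4 is expected to be a step that the limit leaves unreadable from compound 1 to compound 4, most likely reported again as a limit.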

Compound 4, half-maximal inhibitory concentration: 24400 nM
Compound 4: the middle estimate sits 8.2-fold (0.91 log units) above what was measured; the measured number lies below the stated range.
By their numbers in this assay, from the lowest: compounds 4 and 2 (each within the scatter of the next); then compound 3. At a limit, above all of these: compound 1.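

On the amide-type nitrogen, 2-chloro-4-iodophenyl in place of 4-methylphenyl gives an at least 6.1-fold lower number from compound 1 to compound 4 (0.78 log units; beyond the scatter), and the change is read in this assay. Among the compounds shown here, this is the first sign that the aryl group on this nitrogen can move the number in the ester compounds, something the only earlier step, a 3.4-fold higher number from compound 2 to compound 3 (0.53 log units; beyond the scatter), could not show, since it concerns an aromatic carbon in the acid compounds. The size of the new step remains a lower bound because the value for compound 1 is a limit and not a number: the limit of > 150000 nM in this assay, at which 1 of the 4 values shown sits.

The two halogens enter together, so the compounds shown do not separate the share of the chlorine from that of the iodine, and a phenyl ring carrying only one of them, or carrying an amine or a nitrile instead, would address what this position tolerates. Going by these compounds, it also remains open whether the same aryl exchange on the amide-type nitrogen would hold with a carboxylic acid in place of the ethyl ester on the core of compound 4.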